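Swapping a Cyano for a Methoxy on the Aryl Ring

The compounds below may be only part of what the source reports. "The series", "measured", "known", "first", "only" and "open" are said of these compounds alone.

Measured compounds:
compound 1, `COC(=O)c1sc2cc(-c3ccc(-c4cccs4)s3)cnc2c1N`, 1000 nM
compound 2, `COC(=O)c1sc2cc(-c3ccc(C#N)cc3)cnc2c1N`, > 75000 nM

Two compounds share a core and differ only in the group attached to it. In a functional assay on MCF7 cells (Homo sapiens) for inhibition, read by sulforhodamine B assay, with a stated time of 48 h (on this read-out higher numbers stand for weaker inhibition of growth and lower numbers for stronger inhibition of growth), compound 1 gives 1000 nM. For compound 2 the result is only a limit of the assay, > 75000 nM, so no number is known for it. On the numbers shown, compound 2 therefore stands at the weak end, consistent with the limit of > 75000 nM in this assay, at which 1 of the 2 values shown sits.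

Going by the values given here, the next compound, compound 3, `COC(=O)c1sc2cc(-c3ccc(OC)cc3)cnc2c1N`, keeps the same core and changes only one group: methoxy in place of cyano on an aromatic carbon. Among the compounds with values here, no measured pair shows what this change does, so the expectation rests on compound 2 alone, whose value is a limit. The step from compound 2 to compound 3 is expected to be an at least 2.5-fold lower number from compound 2 to compound 3 (0.39 log units; beyond the scatter), with a real chance that only a limit is reported again. Compound 3 is estimated at 30000 nM, with a range from 5000 nM to 150000 nM.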

Compound 3, concentration for 50% growth inhibition: > 150000 nM
Compound 3 ended at the assay's limit (the forecaster's own chance of this, stated with the estimate: 40%); middle value at least 5.0-fold (0.69 log units) from the limit.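

Going by these compounds alone, compound 2 and compound 3 are both reported only as limits of the assay, so swapping cyano for methoxy gives no step that can be read. The compounds shown leave open how far each result lies past its limit, and which of the two groups gives stronger inhibition of growth.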